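This account rests on a few compounds, and the source may have more. Where it says the series, first, only, none or still open, it means among the compounds named here.

Working notes on the series in a functional assay on the whole organism (strain Charles-Foster albino) for inhibition, with Rattus norvegicus as the target, read by paw edema, at a dose of 50 mg/kg by the oral route; a higher number here means more inhibition at the dose given (going by the name of the read-out), a lower number less inhibition. Compound 1 `COc1ccc(C2SCC(=O)N2n2c(CSc3nnc(-c4ccncc4)o3)nc3ccccc3c2=O)cc1` gives 33.8% in this assay, and compound 2 `COc1ccc(C2SCC(=O)N2n2c(CSc3nnc(-c4ccncc4)o3)nc3ccc(Br)cc3c2=O)cc1` gives 35.3%. The step of a number 1.5 percentage points lower from compound 2 to compound 1 (within the scatter) goes with the change (hydrogen in place of bromo on an aromatic carbon). Compound 3 `O=c1c2cc(Br)ccc2nc(CSc2nnc(-c3ccncc3)o2)n1/N=C/c1ccc(Cl)cc1` gives 26.4%; the difference between its core and the core of compound 2 is not broken down here, and their values are within the scatter of each other.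

Compound 4 `O=c1c2ccccc2nc(CSc2nnc(-c3ccncc3)o2)n1/N=C/c1ccc(Cl)cc1` is not yet measured. It differs from compound 3 by hydrogen in place of bromo on an aromatic carbon, the same change as from compound 2 to compound 1, with the same placing on the ring. The step of a number 1.4 percentage points lower from compound 3 to compound 4 (within the scatter) is expected to be small, because a number 1.5 percentage points lower from compound 2 to compound 1 (within the scatter) stayed within the scatter. Compound 4 is estimated at 25%, likely between 15% and 35%.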

Compound 4, a percentage reported as inhibition, in the whole organism at one dose (the size of the read-out at that dose, not a potency): 23.7%
Compound 4: the middle estimate sits 1.3 percentage points above what was measured; low and high end bracket the measured number.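

In this assay, hydrogen in place of bromo on an aromatic carbon gives a number 2.7 percentage points lower from compound 3 to compound 4 (within the scatter), and the change reads alike on the two cores: the same change on two cores in this assay, a number 1.5 percentage points lower (within the scatter) from compound 2 to compound 1 and a number 2.7 percentage points lower (within the scatter) from compound 3 to compound 4, 1.2 percentage points apart, within the scatter of two such steps. Within these two pairs, then, the step carries over from one core to the other, and neither pair shows a change beyond the scatter. This does not show that bromo has any effect on the read-out, and two pairs at a single dose give no potency and say nothing about other cores.

The compounds shown leave open whether another group at this place, such as an amine or a carboxylic acid, would move the number beyond the scatter.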